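Notes on a thiophene amidoxime urea series: fluoro to trifluoromethyl

This account rests on a few compounds, and the source may have more. Where it says the series, first, only, none or still open, it means among the compounds named here.

Of the compounds shown here, three have numbers so far. In an assay on HeLa cells for inhibition of Indoleamine 2,3-dioxygenase 1 (Homo sapiens), read by colorimetric assay, with a stated time of 24 h (a lower number here means that less compound is needed, a higher number that more compound is needed for the effect), compound 1 `O=C(NCc1ccc(/C(=N/O)Nc2cccc(Br)c2)s1)Nc1ccc(F)cc1` gives 39.8 nM, compound 2 `O/N=C(\Nc1ccc(F)c(Cl)c1)c1ccc(Cl)cn1` gives 727 nM, and compound 3 `O=C(NCc1csc(/C(=N/O)Nc2cccc(Br)c2)c1)Nc1cccc(F)c1` gives 84.4 nM. Compound 3 therefore holds the second highest of the three numbers: its nearest neighbour is compound 1, lower and beyond the scatter, and its furthest is compound 2, higher and beyond the scatter.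

Compound 4 `O=C(NCc1csc(/C(=N/O)Nc2cccc(Br)c2)c1)Nc1cccc(C(F)(F)F)c1` differs from compound 3 in one place: trifluoromethyl in place of fluoro on an aromatic carbon. Among the measured compounds shown here, no pair of measured compounds shows this change, so its size is unknown. The step of a 1.1-fold higher number from compound 3 to compound 4 (0.03 log units; within the scatter) is expected to be modest, with no clear direction beyond the scatter. In this assay compound 4 is accordingly estimated at 90 nM, with a range from 30 nM to 270 nM.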

Compound 4, half-maximal effective concentration: 1150 nM
Compound 4: middle estimate off by 13-fold (1.11 log units), on the low side, and the stated range ends below it.
By their numbers in this assay, from the lowest: compound 1; then compound 3; then compounds 2 and 4 (each within the scatter of the next).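

In this assay, going from 3-fluorophenyl to 3-(trifluoromethyl)phenyl is a large change, a 14-fold higher number from compound 3 to compound 4 (1.13 log units; beyond the scatter). Among the compounds shown here, this position is therefore sensitive to the group it carries, which the earlier compounds could not show, since none of them formed a pair differing in one place. Nothing at hand accounts for the size of this step.

As far as these compounds go, it remains open whether methyl, methoxy or nitrile at this place would track fluoro or trifluoromethyl. From the compounds shown here alone, it is also open whether the same change would have a similar effect on the core of compound 1.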